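A few compounds are considered here, and "the series" means these few. Any claim that something is new, unique, unknown or untested is made for them only; others in the source may bear on it.

Going by the values given here, in a functional assay on KB-VIN10 cells (Homo sapiens) for inhibition, with a stated time of 72 h (on this read-out higher numbers stand for weaker inhibition and lower numbers for stronger inhibition), compound 1 (`COc1ccc(S(=O)(=O)N2CCc3cccc(-c4ccc(N(C)C)cc4)c32)cc1`) gives 553 nM, the second highest of the three numbers measured so far. Compound 2 (`COc1ccc(S(=O)(=O)n2ccc3cccc(-c4ccc(C#N)cc4)c32)cc1`) lies lower at 146 nM, and compound 3 (`COc1ccc(S(=O)(=O)N2CCc3cccc(-c4c(F)c(F)c(F)c(F)c4F)c32)cc1`) lies higher at 4630 nM. Both gaps to compound 1 are beyond the scatter, and compound 3 shares the core of compound 1.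

The next molecule, compound 4 (`COc1ccc(S(=O)(=O)N2CCc3cccc(-c4ccc(C#N)cc4)c32)cc1`), keeps the core of compound 1 and changes a single group: cyano in place of dimethylamino on an aromatic carbon. Put simply, this is cyano in place of dimethylamino on an aromatic carbon, para to a large group, so 4-(dimethylamino)phenyl becomes 4-cyanophenyl.

Among the compounds with values here, no two measured compounds differ in one place only, so there is no direct precedent for this change. The nearest clue is compound 2, which carries the same 4-cyanophenyl group on a different core and gives 146 nM. The data cannot separate what the core contributes from what the group contributes, so this clue is weak. A moderate move toward stronger inhibition therefore seems likely, and the expected step is a 2.4-fold lower number from compound 1 to compound 4 (0.38 log units; beyond the scatter). Compound 4 is estimated at 230 nM, with an expected range from 70 nM to 750 nM.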

Compound 4, half-maximal inhibitory concentration: 29.2 nM
The estimate for compound 4 lay 7.9-fold (0.90 log units) above the measured number, outside the stated range (below it).
By their numbers in this assay, from the lowest: compound 4; then compound 2; then compound 1; then compound 3.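

In this assay, replacing dimethylamino with cyano on the aromatic carbon, with the rest of the molecule unchanged, gives a 19-fold lower number from compound 1 to compound 4 (1.28 log units; beyond the scatter). Going by these compounds alone, this is the first pair that differs in one place only, so it shows what the earlier compounds could not: on this core, the group at this position can by itself produce a large change, with the cyano compound giving the lower number. Nothing measured here explains the size of this step or the property of either group that drives it.

A single pair cannot show whether the difference reflects something gained with cyano, something lost with dimethylamino, or both, and comparisons with other groups at the same place, such as methoxy, a primary amide or a carboxylic acid, would help to separate these possibilities. As far as these compounds go, it also remains open whether the same exchange would have a similar effect on the different core of compound 2, which would require a partner carrying 4-(dimethylamino)phenyl on that core.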